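Same atoms, new arrangement: from compound 3 to compound 4

The source may hold more compounds than are shown below. What is called first, only, known or untested is meant among the compounds shown, and "the series" means these compounds.

In an ADME assay on microsomes from liver (Rattus norvegicus) for metabolic stability, read by LC-MS, using NADPH, with stated times of 10 min and 60 min (on this read-out lower numbers stand for slow clearance and higher numbers for fast clearance), compound 3 `CCN1CCN(c2cc(CN(C)[C@H]3CCCc4cccnc43)nc(C)n2)CC1` gives 2180 mL/min/kg as its clearance. That places it within the scatter of compound 1 `CN1CCN(c2cc(CN(C)C3CCCc4cccnc43)nc(C3CC3)n2)CC1` at 2440 mL/min/kg on the same read-out. Compound 2 `CN1CCN(c2cc(CN(C)C3CCCc4cccnc43)nc(N)n2)CC1` reads 767 mL/min/kg and so lies on the lower side of compound 3 by more than the scatter.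

Compound 4 `Cc1nc(CN(C)[C@H]2CCCc3cccnc32)cc(N2CCN(C)[C@@H](C)C2)n1` holds the same atoms as compound 3 joined differently, and the change is 3,4-dimethylpiperazin-1-yl in place of 4-ethylpiperazin-1-yl on an aromatic carbon while the rest of the molecule stays as it was. Going by the values given here, the only measured step between two compounds differing in one place is a 3.2-fold lower number from compound 1 to compound 2 (0.50 log units; beyond the scatter) with amino in place of cyclopropyl on an aromatic carbon. That step is modest yet beyond the scatter, but it concerns a different group and gives only a sense of scale. Among the compounds with values here, no measured compound tests a change in the piperazine group itself.

The best anchor is therefore compound 3 at 2180 mL/min/kg as its measured value. The expected change in this assay is none beyond the scatter, with the estimate amounting to a 1.0-fold lower number from compound 3 to compound 4 (0.02 log units; within the scatter) in size. Compound 4 is expected to read 2100 mL/min/kg with an estimated range from 1000 mL/min/kg to 3800 mL/min/kg in this measurement.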

Compound 4, clearance: 1550 mL/min/kg
For compound 4 the middle estimate is 1.4-fold (0.13 log units) above the measured one; the range from low to high includes it.
By their numbers in this assay, from the lowest: compound 2; then compounds 4, 3 and 1 (each within the scatter of the next).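

In this assay, 3,4-dimethylpiperazin-1-yl in place of 4-ethylpiperazin-1-yl gives a 1.4-fold lower number from compound 3 to compound 4 (0.15 log units; within the scatter), the first direct test of this piperazine position, and on this read-out the two compounds cannot be told apart. Rearranging the same atoms within this group, which also adds a defined stereocentre, therefore has no effect that can be separated from ordinary assay noise, whereas the exchange of cyclopropyl for amino at another place on the shared core gives a 3.2-fold lower number from compound 1 to compound 2 (0.50 log units; beyond the scatter), which is beyond the scatter. No supporting measurement bears on why this rearrangement leaves the clearance indistinguishable.

This single pair cannot show whether the position tolerates larger changes, since both groups are piperazines carrying only small alkyl groups, and a morpholine ring or a piperazine bearing a hydroxyethyl chain or a carboxylic acid could read quite differently. The compounds shown also leave open whether the other stereoisomer of 3,4-dimethylpiperazin-1-yl would behave as compound 4 does.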